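Thiourea series on prostate cancer cells: trifluoromethyl step

The source may hold more compounds than are shown below. What is called first, only, known or untested is meant among the compounds shown, and "the series" means these compounds.

Among the compounds with values here, compound 2 `CNC(=O)c1ccc(Oc2cccc(NC(=S)Nc3ccc(F)cc3)c2)nc1` is measured in a functional assay on PC-3 cells (Homo sapiens) for antiproliferative activity, read by MTT assay (a lower number here means a stronger inhibitor, a higher number a weaker inhibitor), and gives 32700 nM, the higher of the two numbers so far. Its neighbour compound 1 `CNC(=O)c1ccc(Oc2cccc(NC(=S)Nc3ccc(F)c(F)c3)c2)nc1` gives 23100 nM in this assay. Within the data shown here, the step of a 1.4-fold higher number from compound 1 to compound 2 (0.15 log units; within the scatter) is the only measured change and it consists of hydrogen in place of fluoro on an aromatic carbon. Compound 3 `CNC(=O)c1ccc(Oc2cccc(NC(=S)Nc3ccc(F)c(C(F)(F)F)c3)c2)nc1` is not yet measured; it differs from compound 2 by trifluoromethyl in place of hydrogen on an aromatic carbon. Among the measured compounds shown here, no measured step introduces a trifluoromethyl, so the one step on record bears only loosely on this change, and it was within the scatter. A modest move to a lower number is nevertheless expected for compound 3 in this assay, as a 2.7-fold lower number from compound 2 to compound 3 (0.44 log units; beyond the scatter), since the small change toward compound 1 gave 23100 nM and a larger substituent is entered here. Compound 3 is estimated at 12000 nM, within 4000 nM to 40000 nM.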

Compound 3, half-maximal inhibitory concentration: 7950 nM
Beside the measured number, compound 3's estimate is 1.5-fold (0.18 log units) above it, within the range that was stated.
By their numbers in this assay, from the lowest: compound 3; then compounds 1 and 2 (each within the scatter of the next).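

In this assay, the position ortho to a fluoro group and meta to a large group now shows a change beyond the scatter, whereas the earlier exchange of fluoro and hydrogen there stayed within it. Trifluoromethyl in place of hydrogen gives a 4.1-fold lower number from compound 2 to compound 3 (0.61 log units; beyond the scatter), and trifluoromethyl in place of fluoro gives a 2.9-fold lower number from compound 1 to compound 3 (0.46 log units; beyond the scatter), so this group gives a lower number than either of the two smaller substituents, though both steps are modest. Nothing on hand explains this difference.

From the compounds shown here alone, whether the lower number is particular to trifluoromethyl remains open, since a chlorine, a methoxy group or a nitrile at this position would test that. All three compounds also keep the same fluoro group and the shared core, so whether the step holds without that fluoro group is unresolved.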